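Moving the chlorine on the sulfonyl aryl ring

The source may hold more compounds than are shown below. What is called first, only, known or untested is meant among the compounds shown, and "the series" means these compounds.

Compound 1 `CN1CCC(n2cc(S(=O)(=O)c3ccccc3Cl)c3cccnc32)C1` is the reference of the set. In an assay on HeLa cells for displacement of a labelled ligand from 5-hydroxytryptamine receptor 6 (Homo sapiens) (a lower number here means a stronger inhibitor, a higher number a weaker inhibitor), compound 1 gives 2.2 nM. Compound 2 `CN1CCC(n2cc(S(=O)(=O)c3cccc(Cl)c3)c3cccnc32)C1` differs from it by 3-chlorophenyl in place of 2-chlorophenyl on a sulfonyl sulfur; in this assay compound 2 gives 1.5 nM, and the step is a 1.5-fold lower number from compound 1 to compound 2 (0.17 log units; within the scatter). Compound 3 `O=S(=O)(c1ccccc1Cl)c1cn(C2CCCNC2)c2ncccc12` carries a different core, the difference from compound 1 being (piperidin-3-yl in place of 1-methylpyrrolidin-3-yl on an aromatic nitrogen); in this assay compound 3 gives 3.7 nM, the step being a 1.7-fold higher number from compound 1 to compound 3 (0.23 log units; within the scatter). Within the data shown here, no single step joins compound 2 and compound 3; their two values simply stand apart by more than the usual scatter.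

Compound 4 `O=S(=O)(c1cccc(Cl)c1)c1cn(C2CCCNC2)c2ncccc12` is not yet measured. It stands to compound 3 as compound 2 stands to compound 1: the change is 3-chlorophenyl in place of 2-chlorophenyl on a sulfonyl sulfur, the same change as between compound 1 and compound 2, made twice among these compounds, and in both cases at a sulfonyl sulfur whose other neighbours are aromatic carbon. The expected step from compound 3 to compound 4 in this assay is a 1.5-fold lower number from compound 3 to compound 4 (0.17 log units; within the scatter), resting only on compound 1 and compound 2 having shown a 1.5-fold lower number from compound 1 to compound 2 (0.17 log units; within the scatter). Compound 4 is therefore expected to give about 2.5 nM in this assay. The likely range for compound 4 is estimated as 1.2 nM to 5 nM.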

Compound 4, inhibition constant: 1.3 nM
Compound 4: middle estimate off by 1.9-fold (0.28 log units), on the high side; low and high end bracket the measured number.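

In this assay the change to 3-chlorophenyl on the core of compound 3 gives a 2.8-fold lower number from compound 3 to compound 4 (0.45 log units; beyond the scatter), and this step cannot be told apart in size from the same change on the core of compound 1: the same change on two cores in this assay, a 1.5-fold lower number (0.17 log units; within the scatter) from compound 1 to compound 2 and a 2.8-fold lower number (0.45 log units; beyond the scatter) from compound 3 to compound 4, 1.9-fold (0.29 log units) apart, within the scatter of two such steps. The change to piperidin-3-yl, read with 3-chlorophenyl on the sulfonyl sulfur, gives a 1.2-fold lower number from compound 2 to compound 4 (0.06 log units; within the scatter), and this too stands level with its earlier reading: the same change on two cores in this assay, a 1.7-fold higher number (0.23 log units; within the scatter) from compound 1 to compound 3 and a 1.2-fold lower number (0.06 log units; within the scatter) from compound 2 to compound 4, 1.9-fold (0.29 log units) apart, within the scatter of two such steps. So across these four compounds each change reads the same on both cores within the scatter, but this does not show that the two chlorine steps differ in size, and two cores say nothing about whether either change would carry to a further core.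

Open, from the compounds shown here alone, is whether the same holds with methoxy or nitrile in place of chlorine on the phenyl ring. Also open, going by these compounds, is how 1-methylpiperidin-3-yl or an open-chain amine would behave on the aromatic nitrogen.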